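Aryl swap at the pyrazoline-type core: compound 3 to compound 4

The source may hold more compounds than are shown below. What is called first, only, known or untested is meant among the compounds shown, and "the series" means these compounds.

Compound 3 `COc1cc(C2CC(c3cc(OC)c(OC)c(OC)c3)=NN2C(C)=O)ccc1OCc1cn(Cc2ccc([N+](=O)[O-])cc2)nn1` stands highest of the three numbers in a functional assay on A549 cells (Homo sapiens) for inhibition, read by sulforhodamine B assay, tested at 10 uM; on this read-out higher numbers stand for more inhibition of growth at the one concentration tested and lower numbers for less inhibition of growth: in this assay compound 3 gives 68%. Compound 1 `COc1cc(C2CC(c3ccc([N+](=O)[O-])cc3)=NN2C(C)=O)ccc1OCc1cn(Cc2ccc([N+](=O)[O-])cc2)nn1` gives 39% in this assay, and compound 2 `COc1cc(C2CC(c3ccc(Br)cc3)=NN2C(C)=O)ccc1OCc1cn(Cc2ccc([N+](=O)[O-])cc2)nn1` gives 0%. The two steps into compound 3 are both beyond the scatter: a number 29 percentage points higher from compound 1 to compound 3 (beyond the scatter) and a number 68 percentage points higher from compound 2 to compound 3 (beyond the scatter). The step of a number 39 percentage points lower from compound 1 to compound 2 (beyond the scatter) shows the same position moving the number the other way.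

Compound 4 `COc1ccc(C2=NN(C(C)=O)C(c3ccc(OCc4cn(Cc5ccc([N+](=O)[O-])cc5)nn4)c(OC)c3)C2)cc1` differs from compound 3 by 4-methoxyphenyl in place of 3,4,5-trimethoxyphenyl on a carbon with a double bond to nitrogen. No measured step exchanges one methoxy-bearing phenyl for another; the three steps shown all concern this position, and each moved this assay by a modest to large amount, so the position is not one where changes pass unnoticed. Compound 1 and compound 2, which carry groups other than the 3,4,5-trimethoxyphenyl here, both sit well under compound 3. On that ground a drop is expected rather than no change, but of uncertain size because a number 29 percentage points higher from compound 1 to compound 3 (beyond the scatter) and a number 68 percentage points higher from compound 2 to compound 3 (beyond the scatter) do not separate the loss of two methoxy groups from the loss of all three.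

The estimate for compound 4 in this assay is 35%, within 5% to 65%; the expected step is a number 33 percentage points lower from compound 3 to compound 4 (beyond the scatter).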

Compound 4, percent growth inhibition at one concentration: 43%
The estimate for compound 4 lay 8 percentage points below the measured number, and the stated range covers the measured number.
By their numbers in this assay, from the lowest: compound 2; then compounds 1 and 4 (each within the scatter of the next); then compound 3.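

In this assay, the step of a number 25 percentage points lower from compound 3 to compound 4 (beyond the scatter) shows that a single methoxy on this phenyl does not keep the level reached with 3,4,5-trimethoxyphenyl. The same 4-methoxyphenyl compares differently with the two other groups at this place: the step of a number 43 percentage points higher from compound 2 to compound 4 (beyond the scatter) sets it clearly apart from 4-bromophenyl, whereas the step of a number 4 percentage points higher from compound 1 to compound 4 (within the scatter) does not separate it from 4-nitrophenyl. Among the four compounds, 3,4,5-trimethoxyphenyl therefore stands alone at the top, 4-bromophenyl alone at the bottom, and 4-methoxyphenyl and 4-nitrophenyl share the middle; no measurement in hand accounts for this order.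

The compounds shown leave open whether a phenyl with two methoxy groups would hold the level of compound 3 or fall to that of compound 4, so the dependence on the number of methoxy groups is still undefined. Also open, from the compounds shown here alone, is how a phenyl bearing an amine or a carboxylic acid in place of the methoxy would read here, and whether this order holds with other groups elsewhere on the shared core.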